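A few compounds are considered here, and "the series" means these few. Any claim that something is new, unique, unknown or untested is made for them only; others in the source may bear on it.

Compound 1 `O=C(O[C@H]1C[C@H](n2cc(F)c(=O)[nH]c2=O)O[C@@H]1COP(=O)(O)Oc1ccc2ncccc2c1)c1ccccc1`: 7300 nM
Compound 2 `C[n+]1cccc(OP(=O)([O-])OC[C@H]2O[C@@H](n3cc(F)c(=O)[nH]c3=O)C[C@@H]2OC(=O)c2ccccc2)c1`: 1260 nM

Both compounds were tested in a functional assay on HeLa cells (Homo sapiens) for cytotoxicity, read by MTT assay, with a stated time of 48 h; on this read-out lower numbers stand for stronger inhibition and higher numbers for weaker inhibition. Compound 2, at 1260 nM, holds the lower of the two numbers. Compound 1, at 7300 nM, stands above it by a margin beyond the usual scatter, so compound 2 is the stronger inhibitor of this pair.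

Compound 3 `O=C(O[C@H]1C[C@H](n2cc(F)c(=O)[nH]c2=O)O[C@@H]1COP(=O)([O-])Oc1ccc[n+](Cc2ccccc2)c1)c1ccccc1` has not yet been measured. It departs from compound 2 by phenyl in place of hydrogen on a saturated chain carbon bound to an aromatic nitrogen, which is phenyl in place of hydrogen on a saturated chain carbon bound to an aromatic nitrogen. The same difference, cut one bond further out, reads methyl to benzyl. Among the measured compounds shown here, no measured pair isolates this change, so the expectation stays close to compound 2, at 1260 nM. In this assay, a small move toward a lower number is expected, one that may not clear the scatter. The estimated change is a 1.4-fold lower number from compound 2 to compound 3 (0.15 log units; within the scatter). For compound 3 the expected value is 900 nM, with an estimated range from 300 nM to 2700 nM.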

Compound 3, half-maximal inhibitory concentration: 530 nM
For compound 3 the middle estimate is 1.7-fold (0.23 log units) above the measured one; the measured number falls inside the stated range.
By their numbers in this assay, from the lowest: compound 3; then compound 2; then compound 1.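

Among the compounds shown here, the nitrogen substituent on the charged ring is the first place where a single change can be read. In this assay, phenyl in place of hydrogen on a saturated chain carbon bound to an aromatic nitrogen, which reads as methyl to benzyl, gives a 2.4-fold lower number from compound 2 to compound 3 (0.38 log units; beyond the scatter). This modest gain, beyond the usual scatter, shows that this position accepts an added aromatic ring of carbon only, without loss of cytotoxicity and with a measurable improvement, though nothing shown gives the reason for the step.

The compounds shown leave open whether the gain belongs to the aromatic ring itself or would also appear with a saturated group such as cyclohexylmethyl, and whether a longer chain such as phenethyl would move the number further in this assay. They also leave open how a benzyl ring carrying a fluorine, a methoxy group, an amine or a carboxylic acid would behave at this position, and whether the step would hold on the other side of the phosphate, with the benzoyl ester replaced by a free hydroxyl.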